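A few compounds are considered here, and "the series" means these few. Any claim that something is new, unique, unknown or untested is made for them only; others in the source may bear on it.

Compound 1 `Nc1scc(CN2CCN(c3cccc(C(F)(F)F)c3)CC2)c1C(=O)c1ccc(Cl)cc1`: 0%
Compound 2 `Nc1scc(CN2CCN(c3ccccc3F)CC2)c1C(=O)c1ccc(Cl)cc1`: 0%

Both were tested in an assay on CHO cells for displacement of a labelled ligand from adenosine receptor A3 (Homo sapiens), read by scintillation counting, with a stated time of 120 min, tested at 10 uM; a lower number here means less inhibition, a higher number more inhibition at the concentration tested (going by the name of the read-out). Compound 2 stands level with compound 1 at the digits shown. Among the compounds with values here, the one measured step, no change at the digits printed from compound 1 to compound 2 (within the scatter), concerns a swap of the whole group on the amine nitrogen in a ring and lies within the scatter. Compound 3 `Nc1scc(CN2CCN(c3ccccc3Cl)CC2)c1C(=O)c1ccc(Cl)cc1` differs from compound 2 by chloro in place of fluoro on an aromatic carbon. Since that single measured step showed no change, no step beyond the scatter is expected here either: no change at the digits printed from compound 2 to compound 3 (within the scatter). Compound 3 is therefore estimated at 0%, with a range from 0% to 15%.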

Compound 3, a percentage reported as inhibition, at one concentration (the size of the read-out at that concentration, not a potency): 0%
Compound 3: the middle estimate sits on the measured number at the digits printed; measured number inside the range.
By their numbers in this assay, from the lowest: compounds 1, 2 and 3 (each within the scatter of the next).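

On the aromatic carbon ortho to a large group, chloro in place of fluoro gives no change at the digits printed from compound 2 to compound 3 (within the scatter) in this assay, so this halogen swap does not separate the two compounds. The comparison of whole groups on the ring nitrogen gives no change at the digits printed from compound 1 to compound 3 (within the scatter), which extends the same flat picture to 2-chlorophenyl. No measurement at hand offers an explanation for these readings. Going by these compounds, whether the shared core can register any inhibition in this assay stays open. So does the outcome with a methoxy group or an amine on this aromatic ring.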